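Benzyl to allyl, starting from an assay limit

The source may report more compounds than this note shows. Statements on the series, on what has been measured and on what is new or still open speak of the compounds shown alone.

compound 1 `COc1ccc(C(OCc2ccccc2)c2cccc3ccccc23)c(OC)c1OC` gives > 20000 nM (a limit)
compound 2 `COc1ccc(C(O)(C/C=C\c2ccccc2)c2cccc3ccccc23)c(OC)c1OC` gives 12800 nM

Compound 1 in a functional assay on MDA-MB-231 cells (Homo sapiens) for inhibition, read by sulforhodamine B assay, with a stated time of 48 h (a higher number here means a weaker inhibitor, a lower number a stronger inhibitor), gives > 20000 nM as a limit and not as a number. Compound 2 gives 12800 nM as a measured value. Compound 3 `C=CCOC(c1ccc(OC)c(OC)c1OC)c1cccc2ccccc12` differs from compound 1 by vinyl in place of phenyl on a saturated chain carbon bound to an oxygen on a saturated carbon with vinyl in place of phenyl on a saturated chain carbon bound to an oxygen on a saturated carbon, which reads benzyl to allyl one bond further out. For the measured compounds named here, no measured step bears on this change, so in this assay the expected step of a number no higher from compound 1 to compound 3 (the limit leaves the size open) is none beyond the scatter. Compound 3 is estimated at 20000 nM with an expected range from 9000 nM to 45000 nM in this estimate.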

Compound 3, half-maximal inhibitory concentration: > 20000 nM
Compound 3 was reported as a limit (the forecaster's own chance of this, stated with the estimate: 65%); the middle value sits exactly at the limit.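

No step can be read from compound 1 to compound 3, because both are reported only as limits: the limit of > 20000 nM in this assay, at which 2 of the 3 values shown sit. The compounds shown leave open whether benzyl to allyl changes the activity of the shared core at all.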